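Benzyl in Place of a Fluoronitrophenoxy Group

A few compounds are considered here, and "the series" means these few. Any claim that something is new, unique, unknown or untested is made for them only; others in the source may bear on it.

Compound 1 `CC(C)(Oc1ccccc1F)C1OCC(C/C=C\CCC(=O)O)C(c2cccnc2)O1`: 45 nM
Compound 2 `CC(C)(Oc1ccc(F)cc1[N+](=O)[O-])C1OCC(C/C=C\CCC(=O)O)C(c2cccnc2)O1`: 20 nM

In an assay for inhibition of Thromboxane-A synthase (Homo sapiens), using microsomes (on this read-out lower numbers stand for stronger inhibition and higher numbers for weaker inhibition), compound 2 gives 20 nM, the lowest of the two numbers. For the measured compounds named here, the single measured step, a 2.3-fold lower number from compound 1 to compound 2 (0.35 log units; beyond the scatter), changed only the aryl ring on the oxygen. Compound 3 `CC(C)(Cc1ccccc1)C1OCC(C/C=C\CCC(=O)O)C(c2cccnc2)O1` differs from compound 2 by a group of 7 heavy atoms (7 carbon; one six-membered aromatic ring of carbon only) in place of a group of 11 heavy atoms (6 carbon, 1 nitrogen, 3 oxygen, 1 fluorine; one six-membered aromatic ring of carbon only), on a saturated chain carbon bound to two saturated chain carbons and a saturated ring carbon. This removes the oxygen and the fluorine and nitro groups together, a broader change than the measured step, so a move back toward the number of compound 1 or beyond it is expected. Compound 3 is estimated at 70 nM, range 20 nM to 250 nM, meaning an expected 3.5-fold higher number from compound 2 to compound 3 (0.54 log units; beyond the scatter).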

Compound 3, half-maximal inhibitory concentration: 12 nM
Beside the measured number, compound 3's estimate is 5.8-fold (0.77 log units) above it; the measured number lies below the stated range.
By their numbers in this assay, from the lowest: compounds 3 and 2 (each within the scatter of the next); then compound 1.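

In this assay, the ether oxygen and the fluorine and nitro groups can all go from this saturated chain carbon without a loss: the swap to benzyl gives a 1.7-fold lower number from compound 2 to compound 3 (0.22 log units; within the scatter). Benzyl also compares well with the simpler 2-fluorophenoxy group, with a 3.8-fold lower number from compound 1 to compound 3 (0.57 log units; beyond the scatter). No measured evidence accounts for this result. On these data alone, whether a longer chain carrying the same ring in place of benzyl would hold numbers at this level stays open, and so does the effect of an amine on the benzyl ring.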